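This account rests on a few compounds, and the source may have more. Where it says the series, first, only, none or still open, it means among the compounds named here.

Working notes on the series. All three measured compounds share one core and differ only in the ring on the amide-type nitrogen: compound 1 `O=C(Nc1ccccc1[N+](=O)[O-])c1ccc(/N=N\c2c[nH]c3ccccc23)cc1` carries a 2-nitrophenyl, compound 2 `O=C(Nc1ccccc1Cl)c1ccc(/N=N\c2c[nH]c3ccccc23)cc1` a 2-chlorophenyl, compound 3 `O=C(Nc1cccc(Cl)c1)c1ccc(/N=N\c2c[nH]c3ccccc23)cc1` a 3-chlorophenyl. In a functional assay on HCT-116 cells (Homo sapiens) for inhibition, read by MTT assay, with a stated time of 72 h (a lower number here means a stronger inhibitor, a higher number a weaker inhibitor), compound 1 gives 208000 nM, the highest of the three numbers. In this assay compound 2 gives 120000 nM, and in the same assay compound 3 gives 80000 nM. Among the measured compounds shown here, the steps are small throughout: a 1.7-fold lower number from compound 1 to compound 2 (0.24 log units; within the scatter), a change that stays within the scatter; a 2.6-fold lower number from compound 1 to compound 3 (0.41 log units; beyond the scatter), the only step beyond it; and a 1.5-fold lower number from compound 2 to compound 3 (0.18 log units; within the scatter), again within the scatter. The series as a whole is flat and weak.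

Compound 4 `COc1ccccc1NC(=O)c1ccc(/N=N\c2c[nH]c3ccccc23)cc1` is the next entry; it differs from compound 1 in one place: methoxy in place of nitro on an aromatic carbon. The step that bears most directly on it is a 1.7-fold lower number from compound 1 to compound 2 (0.24 log units; within the scatter), which exchanges the same nitro on the same aromatic carbon for another single group and moves the number only within the scatter. By analogy the step is expected to be a 1.4-fold lower number from compound 1 to compound 4 (0.14 log units; within the scatter), a small move toward a lower number that stays within the scatter. Compound 4 is therefore estimated at 150000 nM, with a range from 60000 nM to 350000 nM.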

Compound 4, half-maximal inhibitory concentration: 122000 nM
For compound 4 the middle estimate is 1.2-fold (0.09 log units) above the measured one, within the range that was stated.
By their numbers in this assay, from the lowest: compounds 3, 2, 4 and 1 (each within the scatter of the next, the first and the last beyond it).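

In this assay, methoxy in place of nitro on this aromatic carbon, ortho to a large group, gives a 1.7-fold lower number from compound 1 to compound 4 (0.23 log units; within the scatter), so a second replacement of nitro at this position stays within the scatter, as chloro did with a 1.7-fold lower number from compound 1 to compound 2 (0.24 log units; within the scatter). Methoxy and chloro at this one position are not told apart, with a 1.0-fold higher number from compound 2 to compound 4 (0.01 log units; within the scatter), although the two groups differ in atoms and methoxy keeps a hydrogen-bond acceptor; the 2-methoxyphenyl is likewise not separated from the 3-chlorophenyl, with a 1.5-fold higher number from compound 3 to compound 4 (0.18 log units; within the scatter), which leaves the pair of compound 1 and compound 3 as the only one beyond the scatter. Nothing at hand explains why these changes on the ring barely move the number.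

Still open, from the compounds shown here alone, is whether an amine or a carboxylic acid on this aromatic carbon, or a longer chain such as ethoxy in place of methoxy, would leave the number in the same weak band. Also open, going by these compounds, is whether a 3-methoxyphenyl would stay within the scatter of the 2-methoxyphenyl of compound 4.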